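From 4-fluorophenyl to 2-methylphenyl on a shared core

This account rests on a few compounds, and the source may have more. Where it says the series, first, only, none or still open, it means among the compounds named here.

Compound 1 `Nc1ncnn2c([C@@H]3O[C@H](CO)[C@@H](O)[C@H]3O)cc(C#Cc3ccc(F)cc3)c12` and compound 2 `Nc1ncnn2c([C@@H]3O[C@H](CO)[C@@H](O)[C@H]3O)cc(-c3ccc(F)cc3)c12` share one core and differ in a single group. In a functional assay on HL-60 cells (Homo sapiens) for antiproliferative activity, with a stated time of 72 h (on this read-out higher numbers stand for weaker inhibition and lower numbers for stronger inhibition), compound 1 gives > 100000 nM, which is a limit of the assay and not a number. Among the compounds with values here, compound 2 gives 68300 nM, the only actual number so far, so it has no measured neighbour to be ranked against.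

Compound 3 `Cc1ccccc1-c1cc([C@@H]2O[C@H](CO)[C@@H](O)[C@H]2O)n2ncnc(N)c12` keeps the core of compound 2 and swaps one group: 2-methylphenyl in place of 4-fluorophenyl on an aromatic carbon. In words, 2-methylphenyl replaces 4-fluorophenyl on an aromatic carbon.

Within the data shown here, only one measured step bears on this change: an at least 1.4-fold lower number from compound 1 to compound 2 (0.16 log units; that floor lies within the scatter). It involves the same 4-fluorophenyl group, yet it replaces a different group, and its floor lies within the scatter. Among the measured compounds shown here, no measured step exchanges one such ring for another. With so little to go on, no shift beyond the scatter is expected in this assay, and no direction can be favoured with confidence.

The estimated step is a 1.2-fold lower number from compound 2 to compound 3 (0.09 log units; within the scatter). For compound 3 the expected value is 55000 nM, with an estimated range from 15000 nM to 100000 nM.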

Compound 3, half-maximal inhibitory concentration: 48400 nM
Estimate against measurement, compound 3: 1.1-fold (0.06 log units) above, and the stated range covers the measured number.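

In this assay, the only exchange of one ring for another shown at this position gives a 1.4-fold lower number from compound 2 to compound 3 (0.15 log units; within the scatter), so 2-methylphenyl and 4-fluorophenyl, rings of equal heavy-atom count, cannot be told apart here. Set against 2-(4-fluorophenyl)ethynyl, however, 2-methylphenyl gives an at least 2.0-fold lower number from compound 1 to compound 3 (0.31 log units; beyond the scatter), the first step in this series to pass beyond the scatter, although it is only a modest one. Compound 1 gives > 100000 nM, which is a limit of the assay and not a number, and the size of that step rests on it: the limit of > 100000 nM in this assay, at which 1 of the 3 values shown sits.

The two ring exchanges at this position change the methyl and the fluorine together, so a plain phenyl ring, or a ring carrying either group elsewhere, would be needed to separate what each contributes. Every group shown here is built on a carbon-only aromatic ring without hydrogen-bond donors or acceptors, which leaves open how an amine, a carboxylic acid or a small alkyl chain at this position would read out.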